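A few compounds are considered here, and "the series" means these few. Any claim that something is new, unique, unknown or untested is made for them only; others in the source may bear on it.

Working notes on the series.

Three compounds of one core have been run in a functional assay on L1210 cells (Mus musculus) for inhibition, with a stated time of 48 h; on this read-out lower numbers stand for stronger inhibition and higher numbers for weaker inhibition. Compound 2 `CCC(C)N(C(=O)[C@@H](NC(=O)OCc1ccccc1)[C@@H](C)CC)C1(C(=O)NCc2ccccc2)CCN(Cc2ccccc2)CC1` gives 83000 nM and is the weakest of the set. Compound 1 `CCC(C)N(C(=O)[C@H](CC(=O)OC)NC(=O)OCc1ccccc1)C1(C(=O)NCc2ccccc2)CCN(Cc2ccccc2)CC1` gives 5300 nM; the change from compound 2 to compound 1 is (methoxycarbonyl)methyl in place of sec-butyl on a saturated chain carbon bound to an amide-type nitrogen and a carbonyl carbon and the step is a 16-fold lower number from compound 2 to compound 1 (1.19 log units; beyond the scatter). Compound 3 `CC[C@H](C)[C@H](NC(=O)OCc1ccccc1)C(=O)N(C1CC1)C1(C(=O)NCc2ccccc2)CCN(Cc2ccccc2)CC1` gives 11000 nM; its change from compound 2 is cyclopropyl in place of sec-butyl on an amide-type nitrogen and its step is a 7.5-fold lower number from compound 2 to compound 3 (0.88 log units; beyond the scatter). Compound 1 and compound 3 differ by a step beyond the scatter, with compound 1 at the lower number.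

Compound 4 `COC(=O)C[C@H](NC(=O)OCc1ccccc1)C(=O)N(C1CC1)C1(C(=O)NCc2ccccc2)CCN(Cc2ccccc2)CC1` is not yet measured. Its change from compound 3 is (methoxycarbonyl)methyl in place of sec-butyl on a saturated chain carbon bound to an amide-type nitrogen and a carbonyl carbon, the same change as (methoxycarbonyl)methyl in place of sec-butyl on a saturated chain carbon bound to an amide-type nitrogen and a carbonyl carbon, which occurs twice in the series. The cores of compound 3 and compound 2 differ by cyclopropyl in place of sec-butyl on an amide-type nitrogen; the place of the change is worded identically in both pairs, so the change is the same. In this assay compound 4 is expected to show a step of an 11-fold lower number from compound 3 to compound 4 (1.04 log units; beyond the scatter), somewhat smaller than a 16-fold lower number from compound 2 to compound 1 (1.19 log units; beyond the scatter) because the step from compound 2 rests on a single pair and compound 3 already starts lower, at 11000 nM. The estimate for compound 4 in this assay is 1000 nM, within 300 nM to 4000 nM.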

Compound 4, half-maximal inhibitory concentration: 5300 nM
The estimate for compound 4 lay 5.3-fold (0.72 log units) below the measured number; the whole stated range lies below it.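

In this assay the new step for (methoxycarbonyl)methyl in place of sec-butyl is a 2.1-fold lower number from compound 3 to compound 4 (0.32 log units; beyond the scatter), which keeps the direction seen on the other core but not the size: the same change on two cores in this assay, a 16-fold lower number (1.19 log units; beyond the scatter) from compound 2 to compound 1 and a 2.1-fold lower number (0.32 log units; beyond the scatter) from compound 3 to compound 4, 7.5-fold (0.88 log units) apart, beyond the scatter of two such steps The step for cyclopropyl in place of sec-butyl on an amide-type nitrogen, read with (methoxycarbonyl)methyl already present, is no change at the digits printed from compound 1 to compound 4 (within the scatter), so that change does not carry over either: the same change on two cores in this assay, a 7.5-fold lower number (0.88 log units; beyond the scatter) from compound 2 to compound 3 and no change at the digits printed (within the scatter) from compound 1 to compound 4, 7.5-fold (0.88 log units) apart, beyond the scatter of two such steps Across these four compounds the two changes therefore do not add, and the size of a step on one core is a poor guide to its size on the other, but a single set of four shows neither the reason for this nor how either change behaves on a further core.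

The compounds shown leave open whether a carboxylic acid or a longer ester chain on the same saturated chain carbon would behave like (methoxycarbonyl)methyl. They also leave open whether isopropyl or cyclobutyl on the amide-type nitrogen would follow cyclopropyl.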